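Swapping Amino for Phenyl on a Purine-like Core

The compounds below may be only part of what the source reports. "The series", "measured", "known", "first", "only" and "open" are said of these compounds alone.

Measured compounds:
- compound 1, `Nc1ncnc2c1ncn2C[C@@H]1C[C@H](O)c2ccccc21`: > 200000 nM
- compound 2, `Nc1nc(Cl)c2nnn([C@H]3CCCC[C@H]3CO)c2n1`: 95500 nM
- compound 3, `COc1ccc(-c2ncnc3c2ncn3C[C@@H]2C[C@H](CO)c3ccccc32)cc1`: 17600 nM

In an ADME assay on L1210/0 cells (Mus musculus) for cytotoxicity, with a stated time of 48 h (on this read-out higher numbers stand for weaker inhibition and lower numbers for stronger inhibition), compound 1 reaches only a limit of the assay, > 200000 nM, so no number is known for it; this is the limit of > 200000 nM in this assay, at which 1 of the 3 values shown sits. Compound 2 gives 95500 nM in this assay, and compound 3 gives 17600 nM.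

Compound 4, `O[C@H]1C[C@@H](Cn2cnc3c(-c4ccccc4)ncnc32)c2ccccc21`, has not yet been measured. It differs from compound 1 by phenyl in place of amino on an aromatic carbon.

Going by the values given here, no pair of measured compounds differs in one place, so the size of this step cannot be read directly. Compound 3 also carries an aryl group where compound 1 carries amino. In this assay compound 3 gives 17600 nM. For compound 1 only a limit of the assay is known. A step toward stronger inhibition is therefore expected in this assay.

For compound 4 the estimate in this assay is 30000 nM, in the range 8000 nM to 120000 nM, meaning an expected step of an at least 6.6-fold lower number from compound 1 to compound 4 (0.82 log units; beyond the scatter).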

Compound 4, half-maximal inhibitory concentration: > 200000 nM
Compound 4: a limit, no number; the forecaster's own chance of this, stated with the estimate: 20%; middle value at least 6.6-fold (0.82 log units) away from the limit.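

Going by these compounds alone, compound 1 and compound 4 both reach only a limit in this assay, so no step between them can be read: the limit of > 200000 nM in this assay, at which 2 of the 4 values shown sit.

The compounds shown leave open whether phenyl in place of amino on an aromatic carbon changes inhibition in this assay at all, and by how much.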